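This account rests on a few compounds, and the source may have more. Where it says the series, first, only, none or still open, it means among the compounds named here.

In an assay on isolated protein for inhibition of aldehyde dehydrogenase 1A1 (Homo sapiens), read by spectrophotometry, tested at 10 uM (a lower number here means less inhibition, a higher number more inhibition at the concentration tested (going by the name of the read-out)), three compounds have been measured:

Compound 1 `Cc1cccc(Cn2c(CN3CCN(C(=O)c4ccc(C(C)C)cc4)CC3)nc3ccccc32)c1` gives 67.6%.
Compound 2 `Cc1cccc(Cn2c(CN3CCN(C(=O)c4ccncc4)CC3)nc3ccccc32)c1` gives 20.6%.
Compound 3 `Cc1cccc(Cn2c(CN3CCN(C(=O)C4CCCCC4)CC3)nc3ccccc32)c1` gives 31.9%.

Compound 3 stands second highest of the three. Its nearest neighbour is compound 2, and the step of a number 11.3 percentage points higher from compound 2 to compound 3 (beyond the scatter) places compound 3 modestly above it, beyond the scatter. The step of a number 35.7 percentage points lower from compound 1 to compound 3 (beyond the scatter) shows compound 1 far above compound 3.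

Compound 4 `COc1ccc(C(=O)N2CCN(Cc3nc4ccccc4n3Cc3cccc(C)c3)CC2)cc1` differs from compound 3 in one place: 4-methoxyphenyl in place of cyclohexyl on a carbonyl carbon.

Among the measured compounds shown here, two measured steps bear on this. The step of a number 35.7 percentage points lower from compound 1 to compound 3 (beyond the scatter) shows that trading an aromatic ring, 4-isopropylphenyl, for cyclohexyl on this carbonyl carbon cost a great deal of inhibition; compound 4 returns to an aromatic ring, 4-methoxyphenyl. Yet the step of a number 47 percentage points lower from compound 1 to compound 2 (beyond the scatter) shows that another aromatic ring, pyridin-4-yl, on the same carbonyl carbon lost even more, so an aromatic ring alone does not guarantee the level of compound 1. A rise from compound 3 is therefore expected, likely between these two precedents, as a number 18.1 percentage points higher from compound 3 to compound 4 (beyond the scatter). Compound 4 is estimated at 50%, with a range from 30% to 70%.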

Compound 4, a percentage reported as inhibition, at one concentration (the size of the read-out at that concentration, not a potency): 55.5%
Compound 4: the middle estimate sits 5.5 percentage points below what was measured; the range from low to high includes it.
By their numbers in this assay, from the lowest: compound 2; then compound 3; then compound 4; then compound 1.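

In this assay, the 4-methoxyphenyl ring on this carbonyl carbon gives a clear gain over cyclohexyl, with a number 23.6 percentage points higher from compound 3 to compound 4 (beyond the scatter), and a larger one over pyridin-4-yl, with a number 34.9 percentage points higher from compound 2 to compound 4 (beyond the scatter), so an aromatic ring can raise inhibition here, but the pyridin-4-yl ring of compound 2 goes against any rule that every aromatic ring does. The group carried on the aromatic ring also counts, as a number 12.1 percentage points lower from compound 1 to compound 4 (beyond the scatter) shows for methoxy in place of isopropyl. Nothing available explains why these groups differ.

As far as these compounds go, it remains open how an unsubstituted phenyl ring, or a phenyl ring carrying a tert-butyl group, a chlorine atom or a carboxylic acid, would compare at this position. Also open, from the compounds shown here alone, is whether the same order of groups would hold with changes elsewhere on the shared core.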